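From pyridin-4-yl to pyridin-2-yl: compound 1 to compound 4

The source may report more compounds than this note shows. Statements on the series, on what has been measured and on what is new or still open speak of the compounds shown alone.

Measured in a functional assay on HepG2 cells (Homo sapiens) for antiproliferative activity, read by colorimetric assay and MTT assay, with a stated time of 48 h; on this read-out lower numbers stand for stronger inhibition and higher numbers for weaker inhibition:
- compound 1 `O=C(NS(=O)(=O)c1ccc(F)cc1)c1ccncc1`: 12400 nM
- compound 2 `O=C(NS(=O)(=O)c1ccc(Cl)cc1)c1ccncc1`: 7900 nM
- compound 3 `Cc1ccc(S(=O)(=O)NC(=O)c2ccncc2)cc1`: 20200 nM

Compound 1 lies within the scatter of both other compounds. The two steps read a 1.6-fold lower number from compound 1 to compound 2 (0.20 log units; within the scatter) and a 1.6-fold higher number from compound 1 to compound 3 (0.21 log units; within the scatter). Only the remaining pair is resolved, with a 2.6-fold higher number from compound 2 to compound 3 (0.41 log units; beyond the scatter).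

Compound 4 `O=C(NS(=O)(=O)c1ccc(F)cc1)c1ccccn1` is the next case, and its difference is pyridin-2-yl in place of pyridin-4-yl on a carbonyl carbon. In words, this is pyridin-2-yl in place of pyridin-4-yl on a carbonyl carbon, with the same atoms joined differently.

Going by the values given here, none of the measured steps touches this place. All three exchange fluoro, chloro or methyl on an aromatic carbon, while pyridin-4-yl stays throughout. Among the compounds with values here, they therefore give no direction for the new change and serve only as a gauge of the spread in this assay so far. Within the data shown here, no measured compound carries pyridin-2-yl, so the range has to stay wide. With no direction available, no step beyond the scatter is expected. The expected step is a 1.1-fold higher number from compound 1 to compound 4 (0.05 log units; within the scatter). For compound 4 the estimated value is 14000 nM, with an expected range of 5000 nM to 40000 nM.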

Compound 4, half-maximal inhibitory concentration: 8500 nM
Compound 4: the middle estimate sits 1.6-fold (0.22 log units) above what was measured; the range from low to high includes it.
By their numbers in this assay, from the lowest: compounds 2, 4, 1 and 3 (each within the scatter of the next, the first and the last beyond it).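

In this assay, a 1.5-fold lower number from compound 1 to compound 4 (0.16 log units; within the scatter) is the only step shown at this place on the carbonyl carbon, and it leaves the two isomers unresolved. The earlier compounds shown here all carried pyridin-4-yl and varied only the fluoro, chloro or methyl group on the aromatic carbon, so they could not show whether this attachment of the ring matters; with fluoro in place, exchanging pyridin-4-yl for pyridin-2-yl, the same atoms joined differently, gives no resolved difference in this read-out. Nothing available accounts for the two isomers reading alike.

Pyridin-2-yl is shown only alongside fluoro, so it remains open whether the same exchange would also go unresolved in the chloro compound 2 or the methyl compound 3, the one pair of pyridin-4-yl compounds that differ beyond the scatter. Also open, on these data alone, is how the place on the carbonyl carbon responds to a group other than these two rings, such as pyridin-3-yl, a plain phenyl ring or a ring carrying an amine or a carboxylic acid.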